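The compounds below may be only part of what the source reports. "The series", "measured", "known", "first", "only" and "open" are said of these compounds alone.

Three amides on a shared core have been measured in a functional assay on PC-3 cells (Homo sapiens) for antiproliferative activity, read by MTT assay, with a stated time of 24 h; on this read-out lower numbers stand for stronger inhibition and higher numbers for weaker inhibition. Compound 1 (`CCn1c(C(=O)N[C@@H](C)C(=O)OC)ccc1C(CC)(CC)c1ccc(OCS(=O)(=O)c2ccccc2)c(C)c1`) reads > 50000 nM, which is a limit of the assay. Compound 2 (`CCn1c(C(=O)NCCN)ccc1C(CC)(CC)c1ccc(OCS(=O)(=O)c2ccccc2)c(C)c1`) gives 6890 nM, and compound 3 (`CCn1c(C(=O)N[C@H](CO)CCO)ccc1C(CC)(CC)c1ccc(OCS(=O)(=O)c2ccccc2)c(C)c1`) gives 12100 nM. These two are not separated, with a 1.8-fold higher number from compound 2 to compound 3 (0.24 log units; within the scatter). Compound 3 therefore stands level with compound 2, and clear of the limit, with an at least 4.1-fold lower number from compound 1 to compound 3 (0.61 log units; beyond the scatter) and an at least 7.2-fold lower number from compound 1 to compound 2 (0.86 log units; beyond the scatter). Compound 4 (`CCn1c(C(=O)N[C@@H](CO)CCCO)ccc1C(CC)(CC)c1ccc(OCS(=O)(=O)c2ccccc2)c(C)c1`) carries a group of 7 heavy atoms (5 carbon, 2 oxygen; no ring) in place of a group of 6 heavy atoms (4 carbon, 2 oxygen; no ring), on an amide-type nitrogen. The larger steps both start from the ester of compound 1, whereas the swap at this amide-type nitrogen from compound 2 to compound 3 moved the number only within the scatter, so no step beyond the scatter is expected in this assay. The expected change is a 1.1-fold lower number from compound 3 to compound 4 (0.04 log units; within the scatter). For compound 4 the estimate is 11000 nM, with an expected range of 4500 nM to 30000 nM.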

Compound 4, half-maximal inhibitory concentration: 13400 nM
Beside the measured number, compound 4's estimate is 1.2-fold (0.09 log units) below it; the measured number falls inside the stated range.
By their numbers in this assay, from the lowest: compounds 2, 3 and 4 (each within the scatter of the next). At a limit, above all of these: compound 1.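

In this assay, the group of 7 heavy atoms on the amide-type nitrogen stays level with 3-hydroxy-1-(hydroxymethyl)propyl, with a 1.1-fold higher number from compound 3 to compound 4 (0.04 log units; within the scatter). It also stays level with the 2-aminoethyl group, with a 1.9-fold higher number from compound 2 to compound 4 (0.29 log units; within the scatter), so compounds 2, 3 and 4 show no step beyond the scatter among them. Compound 1 remains at a limit, so an at least 3.7-fold lower number from compound 1 to compound 4 (0.57 log units; beyond the scatter) gives only a bound: the limit of > 50000 nM in this assay, at which 1 of the 4 values shown sits.

From the compounds shown here alone, whether a carboxylic acid or a much longer chain at this nitrogen would separate from these compounds stays open. So does how an amine on the chain of compound 4 would read.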